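Carbonyl substituent swap on the thioether series

The compounds below may be only part of what the source reports. "The series", "measured", "known", "first", "only" and "open" are said of these compounds alone.

In a functional assay on SW707 cells (Homo sapiens) for antiproliferative activity, with a stated time of 72 h (a higher number here means a weaker inhibitor, a lower number a stronger inhibitor), compound 1 `C#CCSc1cnc2ccccc2c1[Se]CC#CCCl` gives 3.2 ug/mL, while compound 2 `CSc1cnc2ccccc2c1SCC#CCOC(=O)/C=C/c1ccccc1` gives 66.6 ug/mL, the higher of the two numbers recorded so far, so compound 2 is the weaker of the pair in this assay. Compound 3 `CCOC(=O)OCC#CCSc1c(SC)cnc2ccccc12` is not yet measured. It differs from compound 2 in one place: ethoxy in place of 2-phenylethenyl on a carbonyl carbon. Among the compounds with values here, no measured pair shows this change, so its effect in this assay is unknown; the step is expected to stay within the scatter, with at most a modest shift toward a lower number. Compound 3 is therefore estimated at 50 ug/mL, in a range from 15 ug/mL to 150 ug/mL, meaning an expected step of a 1.3-fold lower number from compound 2 to compound 3 (0.12 log units; within the scatter).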

Compound 3, concentration for 50% inhibition: 33.1 ug/mL
The estimate for compound 3 lay 1.5-fold (0.18 log units) above the measured number, and the stated range covers the measured number.
By their numbers in this assay, from the lowest: compound 1; then compounds 3 and 2 (each within the scatter of the next).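

In this assay, within the data shown here, ethoxy in place of 2-phenylethenyl on a carbonyl carbon gives a 2.0-fold lower number from compound 2 to compound 3 (0.30 log units; within the scatter), the first reading of any change at this position. In this pair, the six-membered aromatic ring and the double bond that leave with 2-phenylethenyl are therefore not required to keep the read-out within the scatter. Nothing measured here accounts for this result. Open, going by these compounds, is what an amine or a longer chain on this carbonyl carbon would give, and whether ethoxy gives a similar step on another core.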